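Swapping isopropyl for (pyridin-3-yl)methyl on a sulfur

This account rests on a few compounds, and the source may have more. Where it says the series, first, only, none or still open, it means among the compounds named here.

Measured so far in a functional assay on MV4-11 cells (Homo sapiens) for inhibition, read by resazurin assay, with a stated time of 72 h (on this read-out lower numbers stand for stronger inhibition of growth and higher numbers for weaker inhibition of growth), are three compounds:
compound 1 `COc1ccc(Nc2nccc(-c3c[nH]c4ccccc34)n2)c(OC(F)F)c1` (4770 nM)
compound 2 `COc1ccc(Nc2nccc(-c3sc(SC(C)C)nc3C)n2)c(OC)c1` (5670 nM)
compound 3 `COc1ccc(Nc2nccc(-c3cn(C(C)C)c4ccccc34)n2)c(OC)c1` (3250 nM)

Compound 2 (5670 nM) stands within the scatter of both compound 1 and compound 3, so these three numbers cannot be told apart. Compound 4 `COc1ccc(Nc2nccc(-c3sc(SCc4cccnc4)nc3C)n2)c(OC)c1` is compound 2 with (pyridin-3-yl)methyl in place of isopropyl on a sulfur, and the full count of that swap is (pyridin-3-yl)methyl in place of isopropyl on a sulfur for anyone comparing the two structures. Going by the values given here, no measured pair of compounds shows this swap, so the data offer no direct guide to its size or direction in this assay at this stage. Among the compounds with values here, the only hint is that compound 1 (4770 nM) and compound 3 (3250 nM) lie within the scatter of compound 2 (5670 nM). On that basis the estimated step of a 1.6-fold lower number from compound 2 to compound 4 (0.21 log units; within the scatter) is expected to stay inside the scatter, with a faint lean to a lower number. The estimate for compound 4 is 3500 nM with an expected span from 1000 nM to 10000 nM around it.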

Compound 4, concentration for 50% growth inhibition: 270 nM
The estimate for compound 4 lay 13-fold (1.11 log units) above the measured number, and the stated range ends above it.
By their numbers in this assay, from the lowest: compound 4; then compounds 3, 1 and 2 (each within the scatter of the next).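

In this assay the swap of isopropyl for (pyridin-3-yl)methyl on a sulfur whose other neighbour is an aromatic carbon gives a 21-fold lower number from compound 2 to compound 4 (1.32 log units; beyond the scatter) and counts as a large step, well beyond the scatter. Going by these compounds alone, this is the first direct sign that the group on this sulfur strongly affects growth inhibition, since the earlier compounds included no pair differing in one place. No measurement shown here accounts for this step.

On these data alone, it remains open which part of the entering group carries the step. Benzyl on the same sulfur would separate the effect of the ring from that of its nitrogen, while pyridin-2-ylmethyl or pyridin-4-ylmethyl would test whether the nitrogen's place in the ring matters, and a longer chain would test the distance from sulfur to ring.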